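The compounds below may be only part of what the source reports. "The series", "measured", "known", "first", "only" and "open" are said of these compounds alone.

Among the compounds with values here, compound 1 `Cc1cc(S(=O)(=O)Nc2nc3ccsc3c(=O)n2Cc2ccco2)c(S)cc1Cl` is the only one of three measured compounds for which a functional assay on SR cells (Homo sapiens) for inhibition (a lower number here means a stronger inhibitor of growth, a higher number a weaker inhibitor of growth), reports a number: compound 1 gives 9900 nM. Compound 2 `Cc1cc(S(=O)(=O)Nc2nc3cc(-c4ccccc4)sc3c(=O)n2Cc2ccccc2)c(S)cc1Cl` carries a phenyl group on the same five-membered ring and a benzyl group in place of the furan-containing group; in this assay compound 2 returns only a limit, > 100000 nM. Compound 3 `Cc1cc(S(=O)(=O)Nc2nc3cc(-c4ccc(Cl)cc4)sc3c(=O)n2Cc2ccccc2)c(S)cc1Cl` adds a chlorine to that phenyl ring, and in this assay compound 3 also returns a limit, > 100000 nM. Within the data shown here, the one step between measured compounds, a step that the two limits leave unreadable from compound 2 to compound 3, therefore cannot be sized. Compound 4 `Cc1cc(S(=O)(=O)Nc2nc3cc(-c4ccsc4)sc3c(=O)n2Cc2ccco2)c(S)cc1Cl` keeps the furan-containing group of compound 1 and changes it in one place: thiophen-3-yl in place of hydrogen on an aromatic carbon. Among the measured compounds shown here, no measured pair isolates this change. Compounds 2 and 3, which both carry an aromatic ring at that same carbon, sit at the limit of > 100000 nM in this assay, at which 2 of the 3 values shown sit, though each also differs from compound 1 in the group on the ring nitrogen. Weighing this, a sizeable loss of potency in this assay is expected from compound 1 to compound 4, a 7.1-fold higher number from compound 1 to compound 4 (0.85 log units; beyond the scatter), with a real chance that only a limit is returned. Compound 4 is estimated at 70000 nM, within the range 20000 nM to 300000 nM.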

Compound 4, concentration for 50% growth inhibition: > 100000 nM
Compound 4 gave a limit, no number (the forecaster's own chance of this, stated with the estimate: 55%); middle value at least 1.4-fold (0.15 log units) away from the limit.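

With the furan-containing group held fixed, replacing hydrogen with thiophen-3-yl on the aromatic carbon next to the ring sulfur can now be read on its own in this assay: the change gives an at least 10-fold higher number from compound 1 to compound 4 (1.00 log units; beyond the scatter), and the real loss may be larger, since the value for compound 4 is only a limit. Compounds 2 and 3 could not show this, as each also differs from compound 1 in the group on the ring nitrogen, which left open whether the aromatic ring on this carbon was tied to the loss. All the compounds shown with an aromatic ring on this carbon now sit at one limit, and compound 1, with hydrogen there, is the only one that returns a number: the limit of > 100000 nM in this assay, at which 3 of the 4 values shown sit.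

With only limits for these three compounds, the steps among them cannot be read, so thiophen-3-yl, phenyl and chlorine-bearing phenyl cannot be ranked. From the compounds shown here alone, it also stays open whether a much smaller group on this carbon, such as methyl, a single chlorine or an amine, would still give a measurable number in this assay.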